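This account rests on a few compounds, and the source may have more. Where it says the series, first, only, none or still open, it means among the compounds named here.

Measured in a functional assay on brain (Rattus norvegicus, strain Wistar) for inhibition; a lower number here means a stronger inhibitor, a higher number a weaker inhibitor:
- compound 1 `CCCCOc1ccc(-c2c(C)[nH]c(=O)n2C2CCCCC2)cc1`: 13900 nM
- compound 2 `Cc1[nH]c(=O)n(C2CCCCC2)c1-c1ccc(CC(C)C)cc1`: 10900 nM
- compound 3 `CCCCCc1ccc(-c2c(C)[nH]c(=O)n2C2CCCCC2)cc1`: 10600 nM

Compound 3 cannot be separated from the other two compounds on these numbers: a 1.3-fold lower number from compound 1 to compound 3 (0.12 log units; within the scatter), and a 1.0-fold lower number from compound 2 to compound 3 (0.01 log units; within the scatter).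

The next compound, compound 4 `Cc1[nH]c(=O)n(C2CCCCC2)c1-c1ccc(OCCC(C)C)cc1`, has isopentyloxy in place of pentyl on an aromatic carbon, para to a large group: isopentyloxy in place of pentyl on an aromatic carbon.

Within the data shown here, two measured steps bear most directly on this change, as both replace butoxy with a chain lacking the oxygen: a 1.3-fold lower number from compound 1 to compound 2 (0.11 log units; within the scatter), and a 1.3-fold lower number from compound 1 to compound 3 (0.12 log units; within the scatter). The change in compound 4 runs the opposite way, from a chain without oxygen to one with it. Among the measured compounds shown here, the step between the isobutyl of compound 2 and the pentyl of compound 3 gives the only measured comparison of chain shape, and it also stays within the scatter. No step beyond the scatter is therefore expected in this assay. The expected step is a 1.1-fold higher number from compound 3 to compound 4 (0.04 log units; within the scatter). The estimated value for compound 4 is 11500 nM, with an expected range of 5500 nM to 24000 nM.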

Compound 4, half-maximal inhibitory concentration: 7200 nM
Beside the measured number, compound 4's estimate is 1.6-fold (0.20 log units) above it; low and high end bracket the measured number.
By their numbers in this assay, from the lowest: compounds 4, 3, 2 and 1 (each within the scatter of the next).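

In this assay, isopentyloxy on this aromatic carbon, para to a large group, gives a 1.5-fold lower number from compound 3 to compound 4 (0.17 log units; within the scatter) and a 1.5-fold lower number from compound 2 to compound 4 (0.18 log units; within the scatter), so a chain carrying an oxygen and one hydrogen-bond acceptor is not separated here from the all-carbon pentyl and isobutyl chains. Against butoxy, the added methyl gives a 1.9-fold lower number from compound 1 to compound 4 (0.29 log units; within the scatter) and this also stays within the scatter, so all four compounds remain one group with no order among them. No measurement in hand explains these small steps.

Still open, on these data alone, is whether any group at this position can move the number beyond the scatter, which an amine, a carboxylic acid or a much shorter chain such as methoxy would test. As far as these compounds go, the rest of the shared core is the same in all four compounds, so its part in the inhibition remains unknown.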